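The compounds below may be only part of what the source reports. "The series", "measured", "known", "first", "only" and "open" are said of these compounds alone.

Measured in a physicochemical assay for solubility, in phosphate buffer, with a stated time of 24 h, at pH 7.4, tested at 100 uM; a higher number here means a more soluble compound, a lower number a less soluble compound:
- compound 1 `CCCn1cc(S(=O)(=O)c2ccc(CNC(=O)N3Cc4ccncc4C3)cc2)cn1`: 105000 nM
- compound 2 `O=C(NCc1ccc(S(=O)(=O)C2CCOCC2)cc1)N1Cc2ccncc2C1`: 206000 nM
- compound 3 `O=C(NCc1ccc(S(=O)(=O)N2CCOCC2)cc1)N1Cc2ccncc2C1`: 59000 nM

Compound 3 stands apart beyond the scatter from one measured neighbour only: a 3.5-fold lower number from compound 2 to compound 3 (0.54 log units; beyond the scatter). The other gap, a 1.8-fold lower number from compound 1 to compound 3 (0.25 log units; within the scatter), stays within the scatter.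

Compound 4 `O=C(NCc1ccc(S(=O)(=O)N2CC3(CCOCC3)C2)cc1)N1Cc2ccncc2C1` carries this change: a group of 9 heavy atoms (7 carbon, 1 nitrogen, 1 oxygen; one four-membered non-aromatic ring with 1 hetero atom, one six-membered non-aromatic ring with 1 hetero atom) in place of a group of 6 heavy atoms (4 carbon, 1 nitrogen, 1 oxygen; one six-membered non-aromatic ring with 2 hetero atoms), on a sulfonyl sulfur. Within the data shown here, no measured step covers the entering group. Among the measured compounds shown here, the swaps on the sulfonyl sulfur are the only guide: a 2.0-fold higher number from compound 1 to compound 2 (0.29 log units; within the scatter) also lies within the scatter, and the largest, a 3.5-fold lower number from compound 2 to compound 3 (0.54 log units; beyond the scatter), is modest. With steps of that size, no change beyond the scatter is expected in this assay, in either direction. The expected step is a 1.0-fold higher number from compound 3 to compound 4 (0.01 log units; within the scatter). Compound 4 is estimated at 60000 nM, with an expected range of 20000 nM to 170000 nM.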

Compound 4, solubility: 272000 nM
For compound 4 the middle estimate is 4.5-fold (0.66 log units) below the measured one; the measured number lies above the stated range.
By their numbers in this assay, from the lowest: compounds 3, 1, 2 and 4 (each within the scatter of the next, the first and the last beyond it).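

In this assay, the sulfonyl sulfur carries the largest group so far, with its four-membered and six-membered non-aromatic rings, and the number does not fall: a 4.6-fold higher number from compound 3 to compound 4 (0.66 log units; beyond the scatter) and a 2.6-fold higher number from compound 1 to compound 4 (0.41 log units; beyond the scatter) both go upward. Against the oxan-4-yl group, the same group gives a 1.3-fold higher number from compound 2 to compound 4 (0.12 log units; within the scatter), so the two cannot be told apart here. Nothing shown accounts for these steps.

Open, from the compounds shown here alone, is whether the four-membered ring alone, without the six-membered ring, or a group bearing a basic amine on the sulfonyl sulfur would keep numbers of this size.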